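The compounds below may be only part of what the source reports. "The series", "measured", "known", "first", "only" and "open" are said of these compounds alone.

Working notes, a functional assay on RAW264.7 cells (Mus musculus) for inhibition, with a stated time of 4 days; a higher number here means a weaker inhibitor, a lower number a stronger inhibitor. Compound 1 `COc1cc(/C=C/C(=O)c2cccc(N=[N+]=[N-])c2)ccc1O` gives 7110 nM in this assay. Compound 2 `COc1cc(/C=C/C(=O)c2cccc(-n3cc(C(C)(C)O)nn3)c2)ccc1O` gives 19800 nM, and compound 3 `COc1ccc(/C=C/C(=O)c2cccc(-n3cc(C(C)(C)O)nn3)c2)cc1O` gives 17100 nM. Among the compounds with values here, of the three numbers compound 3 stands second highest; its nearest neighbour is compound 2, with a 1.2-fold lower number from compound 2 to compound 3 (0.06 log units; within the scatter) lying within the scatter, while compound 1 sits clearly lower, the only step beyond the scatter in the set being a 2.8-fold higher number from compound 1 to compound 2 (0.44 log units; beyond the scatter), where 4-(1-hydroxy-1-methylethyl)-1H-1,2,3-triazol-1-yl replaces azido.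

Compound 4 `COc1ccc(/C=C/C(=O)c2cccc(-n3cc(-c4ccc(C)cc4)nn3)c2)cc1O` is not yet measured and differs from compound 3 by 4-methylphenyl in place of 1-hydroxy-1-methylethyl on an aromatic carbon. Within the data shown here, no measured step touches this position: one exchanged azido for the whole triazole, the other swapped 3-hydroxy-4-methoxyphenyl for 4-hydroxy-3-methoxyphenyl on the chain. Nothing here shows how the triazole carbon tolerates a 4-methylphenyl, so any expectation is weakly grounded and taken as a modest step in either direction, centred near no change. Compound 4 is therefore expected at about 12000 nM, with a range from 4000 nM to 40000 nM, corresponding to an expected step of a 1.4-fold lower number from compound 3 to compound 4 (0.15 log units; within the scatter).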

Compound 4, half-maximal inhibitory concentration: 1700 nM
Beside the measured number, compound 4's estimate is 7.1-fold (0.85 log units) above it, outside the stated range (below it).
By their numbers in this assay, from the lowest: compound 4; then compound 1; then compounds 3 and 2 (each within the scatter of the next).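

In this assay, the aromatic carbon of the five-membered ring with 3 nitrogen proves to be a position where the group strongly affects the read-out: 4-methylphenyl in place of 1-hydroxy-1-methylethyl gives a 10-fold lower number from compound 3 to compound 4 (1.00 log units; beyond the scatter), a larger step than either earlier one. Within this pair, a low number does not require the hydrogen-bond donor and acceptor of the leaving group, since the entering all-carbon aromatic ring has neither. No measurement is at hand that explains this step.

Within the data shown here, the single exchange changes ring, size and hydroxyl together, so the contribution of each remains unresolved. Going by these compounds, what a plain phenyl, a cyclohexyl or an aminomethyl group would give at this position stays open, as does whether the step holds with the 4-hydroxy-3-methoxyphenyl group on the chain.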